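This account rests on a few compounds, and the source may have more. Where it says the series, first, only, none or still open, it means among the compounds named here.

Of the compounds shown here, two built on a shared core have been tested in a functional assay on PC-3M cells (Homo sapiens) for cytotoxicity, read by MTT assay, with a stated time of 48 h; a higher number here means a weaker inhibitor, a lower number a stronger inhibitor. Compound 1 `CCCc1nnc(SCC(=O)c2ccc(Cl)cc2)n1N1C(=O)c2ccccc2C1=O` gives > 200000 nM in this assay, which is a limit of the assay rather than a measured number. Compound 2 `CCCc1nnc(SCC(=O)c2ccccc2)n1N1C(=O)c2ccccc2C1=O` gives > 200000 nM in this assay, again a limit. Going by the values given here, the step that the two limits leave unreadable from compound 1 to compound 2 therefore cannot be read in size, and the only evidence available is the limit of > 200000 nM in this assay, at which 2 of the 2 values shown sit. Compound 3 `CCCc1nnc(SC)n1N1C(=O)c2ccccc2C1=O` differs from compound 2 by hydrogen in place of benzoyl on a saturated chain carbon bound to a sulfur. Among the compounds with values here, no measured step covers this change, and the one measured step is unreadable, so nothing among the values shown gives a basis for expecting compound 3 to move off the limit. Compound 3 is estimated at 200000 nM, within 50000 nM to 1000000 nM, and is expected most likely to be reported again as a limit. The expected step of a number no higher from compound 2 to compound 3 (the limit leaves the size open) is no change beyond the scatter.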

Compound 3, half-maximal inhibitory concentration: > 200000 nM
Compound 3 gave a limit, no number; the forecaster's own chance of this, stated with the estimate: 85%; the middle value lies on the limit itself.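

Going by these compounds alone, compound 1, compound 2 and compound 3 all sit at the same assay limit, so no step among them can be read: the limit of > 200000 nM in this assay, at which 3 of the 3 values shown sit. The compounds shown leave open whether the chloro, or benzoylmethyl against methyl, makes any difference to the cytotoxicity of the shared core.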